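The compounds below may be only part of what the source reports. "The series", "measured", "known", "first", "only" and "open" are said of these compounds alone.

Of the compounds shown here, three sharing one core have so far been measured in a functional assay on a cell-free system (plasma) for inhibition of thromboxane A2 receptor (Homo sapiens); a higher number here means a weaker inhibitor, a lower number a stronger inhibitor. Compound 1, `CSCSCC1C2CCC(O2)C1C/C=C\CCCC(=O)O`, gives 700 nM. Compound 2, `CCCCSCSCC1C2CCC(O2)C1C/C=C\CCCC(=O)O`, gives 700 nM, and the step of no change at the digits printed from compound 1 to compound 2 (within the scatter) is propyl in place of hydrogen on a saturated chain carbon bound to a sulfur. Compound 3, `O=C(O)CCC/C=C\CC1C2CCC(O2)C1CSCCc1ccccc1`, gives 5500 nM, the highest of the three numbers and so the weakest inhibitor of the set; the steps of a 7.9-fold higher number from compound 1 to compound 3 (0.90 log units; beyond the scatter) and a 7.9-fold higher number from compound 2 to compound 3 (0.90 log units; beyond the scatter) both put benzyl in place of methylsulfanyl or butylsulfanyl on a saturated chain carbon bound to a sulfur.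

Compound 4, `O=C(O)CCC/C=C\CC1C2CCC(O2)C1CSCCCc1ccccc1`, differs from compound 3 by benzyl in place of phenyl on a saturated chain carbon, two bonds along the chain from a sulfur; cut one bond further out, this reads phenethyl to 3-phenylpropyl. Within the data shown here, no measured step lengthens the chain at this place, so the question is open. The nearest comparison is the step of no change at the digits printed from compound 1 to compound 2 (within the scatter), where a longer chain on a saturated chain carbon bound to a sulfur left the number unchanged. On that basis a step of a 1.2-fold lower number from compound 3 to compound 4 (0.09 log units; within the scatter) is expected in this assay, small and within the scatter. Compound 4 is therefore estimated at 4500 nM, with a range from 1500 nM to 13000 nM.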

Compound 4, half-maximal inhibitory concentration: 5000 nM
Compound 4: the middle estimate sits 1.1-fold (0.05 log units) below what was measured; low and high end bracket the measured number.
By their numbers in this assay, from the lowest: compounds 1 and 2 (each within the scatter of the next); then compounds 4 and 3 (each within the scatter of the next).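

In this assay, among these compounds, the chain ending in phenyl can be extended from phenethyl to 3-phenylpropyl with no change beyond the scatter, as a 1.1-fold lower number from compound 3 to compound 4 (0.04 log units; within the scatter) shows, so this is the first sign that the phenyl-ended chain tolerates this change at this position. The gap to the sulfur-containing chains also holds for the longer phenyl-ended chain, with a 7.1-fold higher number from compound 2 to compound 4 (0.85 log units; beyond the scatter) and a 7.1-fold higher number from compound 1 to compound 4 (0.85 log units; beyond the scatter), so compounds 3 and 4 both give higher numbers than compounds 1 and 2, and none of the four goes against this. Nothing measured here offers an explanation for either the flat step or the gap.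

The compounds shown leave open whether a still longer chain such as 4-phenylbutyl would stay level with compounds 3 and 4, and whether a plain alkyl chain such as butyl, with neither the phenyl ring nor the second sulfur, would fall with compounds 1 and 2 or with compounds 3 and 4. They also say nothing about how an amine or a hydroxyl group on the phenyl ring would affect the number.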